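This account rests on a few compounds, and the source may have more. Where it says the series, first, only, none or still open, it means among the compounds named here.

Going by the values given here, compound 3 `COc1cc(N)c(Cl)cc1C(=O)CCC1CCN(CCNS(=O)(=O)c2ccc(N)c(Br)c2)CC1` gives 5.3 nM in an assay on brain for displacement of a labelled ligand from 5-hydroxytryptamine receptor 4 (Cavia porcellus), with a stated time of 30 min, in the presence of a further agent that is not named here (a lower number here means a stronger inhibitor, a higher number a weaker inhibitor), the lowest of the three numbers so far; compound 2 `COc1cc(N)c(Cl)cc1C(=O)CCC1CCN(CCNS(=O)(=O)c2ccc3c(c2)NC(=O)CO3)CC1` gives 6.2 nM and compound 1 `COc1cc(N)c(Cl)cc1C(=O)CCC1CCN(CCNS(=O)(=O)c2cc(Br)ccc2Br)CC1` gives 16.3 nM. The gap a 1.2-fold lower number from compound 2 to compound 3 (0.07 log units; within the scatter) lies within the scatter, while a 3.1-fold lower number from compound 1 to compound 3 (0.49 log units; beyond the scatter) and a 2.6-fold lower number from compound 1 to compound 2 (0.42 log units; beyond the scatter) are modest but beyond it. Compound 4 `COc1cc(N)c(Cl)cc1C(=O)CCC1CCN(CCNS(=O)(=O)c2cc(Br)c(N)c(Br)c2)CC1` carries bromo in place of hydrogen on an aromatic carbon. Among the compounds with values here, no measured step adds a single bromo to an otherwise unchanged ring; the nearest comparison is compound 1, whose 2,5-dibromophenyl gives the highest number. Because a 3.1-fold lower number from compound 1 to compound 3 (0.49 log units; beyond the scatter) is only modest, a further bromo on the amino-bearing ring is expected to shift little. The step of a 1.2-fold higher number from compound 3 to compound 4 (0.09 log units; within the scatter) is expected to stay within the scatter. In this assay compound 4 is estimated at 6.5 nM, range 2.5 nM to 17 nM.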

Compound 4, inhibition constant: 8.7 nM
Compound 4: middle estimate off by 1.3-fold (0.13 log units), on the low side; the range from low to high includes it.
By their numbers in this assay, from the lowest: compounds 3, 2, 4 and 1 (each within the scatter of the next, the first and the last beyond it).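

At the position ortho to an amino group, a bromo leaves the number within the scatter: a 1.6-fold higher number from compound 3 to compound 4 (0.22 log units; within the scatter) in this assay does not separate 4-amino-3,5-dibromophenyl from 4-amino-3-bromophenyl. The steps of a 1.4-fold higher number from compound 2 to compound 4 (0.15 log units; within the scatter) and a 1.9-fold lower number from compound 1 to compound 4 (0.27 log units; within the scatter) also stay within the scatter, so compound 4 is separated from none of the other three, although compound 1 and compound 3 are separated from each other. No evidence on the origin of these steps is available. On these data alone, whether chloro or methyl at this position behaves like bromo remains open. So does the outcome of a hydroxyl in place of the amino group.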